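Moving the chlorine around the phenyl ring of a thiourea

The source may hold more compounds than are shown below. What is called first, only, known or untested is meant among the compounds shown, and "the series" means these compounds.

Measured so far in a functional assay on thoracic aorta (Rattus norvegicus) for inhibition; a higher number here means that more compound is needed for the effect, a lower number that less compound is needed:
- compound 1 `CC1(C)CC(NC(=S)Nc2ccc(Cl)cc2)c2cc(NS(C)(=O)=O)ccc2O1` gives 11600 nM
- compound 2 `CCS(=O)(=O)Nc1ccc2c(c1)C(NC(=S)Nc1cccc(C#N)c1)CC(C)(C)O2` gives 12100 nM
- compound 3 `CCS(=O)(=O)Nc1ccc2c(c1)C(NC(=S)Nc1cccc(Cl)c1)CC(C)(C)O2` gives 9800 nM

Of these three numbers, compound 3 shows the lowest one, but the gaps are small: compound 1 is closest, compound 2 furthest, and both lie within the scatter of repeated measurements, so no order among the three can be claimed.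

Compound 4 `CCS(=O)(=O)Nc1ccc2c(c1)C(NC(=S)Nc1ccc(Cl)cc1)CC(C)(C)O2` has not yet been measured in this assay. It keeps every atom of compound 3 and differs only in how they are joined: 4-chlorophenyl in place of 3-chlorophenyl on an amide-type nitrogen.

For the measured compounds named here, only one measured step speaks to this region of the molecule, the exchange a 1.2-fold lower number from compound 2 to compound 3 (0.09 log units; within the scatter), and it changed nothing beyond the scatter. Compound 1 also carries a 4-chlorophenyl group, but it differs from compound 3 in a second place as well, so its value can only be set beside that of compound 3, where the two sit close together. Taken together, these numbers give no reason to expect a change beyond the scatter from compound 3 to compound 4.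

Compound 4 is therefore expected to give about 11000 nM in this assay, in a range of 6000 nM to 20000 nM, meaning an estimated step of a 1.1-fold higher number from compound 3 to compound 4 (0.05 log units; within the scatter).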

Compound 4, half-maximal effective concentration: 5100 nM
Compound 4: the middle estimate sits 2.2-fold (0.33 log units) above what was measured; the whole stated range lies above it.
By their numbers in this assay, from the lowest: compounds 4, 3, 1 and 2 (each within the scatter of the next, the first and the last beyond it).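

In this assay, moving the chlorine from 3-chlorophenyl to 4-chlorophenyl gives a 1.9-fold lower number from compound 3 to compound 4 (0.28 log units; within the scatter), so this exchange alone cannot be said to alter the result. The exchange of 3-cyanophenyl for 4-chlorophenyl on the same amide-type nitrogen does clear the scatter, though only modestly, with a 2.4-fold lower number from compound 2 to compound 4 (0.38 log units; beyond the scatter). With the 4-chlorophenyl group held constant, compound 1 and compound 4 now also form a clean single-place pair, and methyl in place of hydrogen on the carbon bound to the sulfonyl sulfur gives a 2.3-fold lower number from compound 1 to compound 4 (0.36 log units; beyond the scatter), showing that the sulfonyl end of the molecule can count as well.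

As far as these compounds go, whether a propyl chain on the sulfonyl sulfur, or a methoxy group in place of the chlorine, would go further remains open. The data shown offer no explanation for any of these differences.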